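The source may hold more compounds than are shown below. What is called first, only, known or untested is meant among the compounds shown, and "the series" means these compounds.

Measured so far:
- compound 1, `OC[C@H]1O[C@@H](n2cnc3c(NCc4ccco4)ncnc32)[C@H](O)[C@@H]1O`: 36300 nM
- compound 2, `Cc1cccc(CSc2nc(N)nc3c2ncn3[C@@H]2O[C@H](CO)[C@@H](O)[C@H]2O)n1`: 11500000 nM

In an assay on isolated protein for binding affinity to Equilibrative nucleoside transporter 1 (Homo sapiens) (on this read-out higher numbers stand for weaker inhibition and lower numbers for stronger inhibition), compound 1 gives 36300 nM, the lowest of the two numbers; compound 2 gives 11500000 nM, a much higher number, well beyond the usual scatter. Compound 3, `OC[C@H]1O[C@@H](n2cnc3c(CSc4ccc(F)cc4)ncnc32)[C@H](O)[C@@H]1O`, is not yet measured in this assay. It differs from compound 1 in one place: ((4-fluorophenyl)sulfanyl)methyl in place of ((furan-2-yl)methyl)amino on an aromatic carbon. The change removes the only hydrogen-bond donor of the leaving group and brings in a six-membered aromatic ring of carbon only with a fluorine, joined to the shared core through a sulfur-containing methyl linker. For the measured compounds named here, no measured pair of compounds shows a step of this kind, so the direction has to be guessed from the two values alone. A modest weakening is expected for compound 3, a step of a 2.8-fold higher number from compound 1 to compound 3 (0.44 log units; beyond the scatter) in this assay, with wide uncertainty. Compound 3 is therefore estimated at 100000 nM, somewhere between 10000 nM and 2000000 nM.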

Compound 3, half-maximal inhibitory concentration: 158 nM
Compound 3: the middle estimate sits 630-fold (2.80 log units) above what was measured; measured number below the stated range.
By their numbers in this assay, from the lowest: compound 3; then compound 1; then compound 2.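

This aromatic carbon of the shared core proves highly sensitive to the group it carries: in this assay, placing ((4-fluorophenyl)sulfanyl)methyl there in place of ((furan-2-yl)methyl)amino gives a 230-fold lower number from compound 1 to compound 3 (2.36 log units; beyond the scatter). A hydrogen-bond donor in this group is therefore not required for a low number, as the entering group has none and compound 3 still gives a far lower number than compound 1. No separate measurement is available to explain why the number falls.

The ring, the sulfur-containing linker and the fluorine all change in this single step, so it remains open which of them accounts for the shift. A plain phenyl ring without fluorine, a methoxy group in place of the fluorine, or an amine linker carrying the same fluorinated ring would help to separate these parts.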